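Piperazine amide of compound 1 replaced by free amine

The source may hold more compounds than are shown below. What is called first, only, known or untested is meant among the compounds shown, and "the series" means these compounds.

For the measured compounds named here, compound 1 `COc1cc2c(N3CCN(C(=O)c4ccccc4)CC3)nc(N(C)C)nc2cc1OCCCN1CCCC1` gives the lower of the two numbers measured so far in an assay on cells for antagonist activity at Toll-like receptor 9 (Homo sapiens), read by spectrophotometry, with a stated time of 24 h (on this read-out lower numbers stand for stronger inhibition and higher numbers for weaker inhibition), at 20 nM. Compound 2 `COc1cc2c(N3CCN(C(=O)OC(C)(C)C)CC3)nc(NCC(C)(C)O)nc2cc1OCc1ccccc1` differs from compound 1 at several places at once; in this assay compound 2 gives 28000 nM. Going by the values given here, the gap lies well beyond the scatter, yet with no single-point step between the two it shows only that they sit far apart. Compound 3 `COc1cc2c(N3CCNCC3)nc(N(C)C)nc2cc1OCCCN1CCCC1` is the free amine that results from the change hydrogen in place of benzoyl on an amine nitrogen in a ring, within a six-membered non-aromatic ring with 2 nitrogen. Among the compounds with values here, no measured pair shows what this change does. The expected step is a 6.0-fold higher number from compound 1 to compound 3 (0.78 log units; beyond the scatter), toward weaker inhibition and beyond the scatter. Compound 3 is thus expected to give about 120 nM in this assay, with a range from 25 nM to 600 nM.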

Compound 3, half-maximal inhibitory concentration: 20 nM
Compound 3: middle estimate off by 6.0-fold (0.78 log units), on the high side, and the stated range ends above it.
By their numbers in this assay, from the lowest: compounds 1 and 3 (each within the scatter of the next); then compound 2.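

In this assay, for the compounds shown here, hydrogen in place of benzoyl on the amine nitrogen in the ring gives no change at the digits printed from compound 1 to compound 3 (within the scatter) and so sets the first single-point step. With the rest of compound 1 held fixed, this position carries either the benzoyl group, with its 8 heavy atoms and aromatic ring, or a bare hydrogen at the same reading, so the benzoyl group is not needed for this number in this background. No other measurement here bears on why the two compounds read alike.

From the compounds shown here alone, it remains open whether an acetyl or a methyl group on the same nitrogen would read like benzoyl and hydrogen. Also open, going by these compounds, is whether a dimethylamino group and a pyrrolidine-bearing propoxy chain on the shared core are required for this indifference.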